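Trifluoromethyl in place of the pyrrole on the shared core

A few compounds are considered here, and "the series" means these few. Any claim that something is new, unique, unknown or untested is made for them only; others in the source may bear on it.

Of the compounds shown here, three sharing one core have been measured in a functional assay (aorta) with Rattus norvegicus as the target; on this read-out lower numbers stand for lower potency and higher numbers for higher potency (the scale is a negative logarithm). Compound 1 `CC1(C)C=C(n2ccccc2=O)c2cc(C(=O)c3cccs3)ccc2O1` gives 6.4, compound 2 `CC1(C)C=C(n2ccccc2=O)c2cc(C=C(C#N)C#N)ccc2O1` gives 6.95, and compound 3 `Cc1ccc(C)n1-c1ccc2c(c1)C(n1ccccc1=O)=CC(C)(C)O2` gives 7.27, the highest of the three. Compound 4 `CC1(C)C=C(n2ccccc2=O)c2cc(C(F)(F)F)ccc2O1` differs from compound 3 in one place: trifluoromethyl in place of 2,5-dimethyl-1H-pyrrol-1-yl on an aromatic carbon. Among the compounds with values here, the steps that bear on this position are a number 0.87 log units higher from compound 1 to compound 3 (beyond the scatter) and a number 0.32 log units higher from compound 2 to compound 3 (beyond the scatter), both modest rises on arrival of the 2,5-dimethyl-1H-pyrrol-1-yl group. Its removal for a smaller group is therefore expected to lower this assay by a modest amount, roughly a number 0.67 log units lower from compound 3 to compound 4 (beyond the scatter). For compound 4 the expected value is 6.6, with a range from 6 to 7.2.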

Compound 4, logarithm of the reciprocal of the active concentration, log(1/C): 7.61
Beside the measured number, compound 4's estimate is 1.01 log units below it, and the stated range ends below it.
By their numbers in this assay, from the lowest: compound 1; then compound 2; then compound 3; then compound 4.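

In this assay this position does not depend on the ring of the 2,5-dimethyl-1H-pyrrol-1-yl group, since trifluoromethyl, which has no ring, gives a further rise (a number 0.34 log units higher from compound 3 to compound 4 (beyond the scatter)). Trifluoromethyl also exceeds the other two groups (a number 0.66 log units higher from compound 2 to compound 4 (beyond the scatter); a number 1.21 log units higher from compound 1 to compound 4 (beyond the scatter)), so among these four compounds the highest number belongs to the one group without a ring or a multiple bond. Nothing available explains why this substitution raises the number.

The compounds shown leave open how a single fluorine, a methyl or a methoxy group on this aromatic carbon would compare with trifluoromethyl. They also leave open what an amine or a carboxylic acid would do there.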